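A few compounds are considered here, and "the series" means these few. Any claim that something is new, unique, unknown or untested is made for them only; others in the source may bear on it.

The series shares one core. Compound 1 `Cc1[nH]n(-c2nc3cc(-c4ccccc4)ccc3[nH]2)c(=O)c1Cc1ccccc1` carries a phenyl on its fused ring system and a plain benzyl group, and in an assay on isolated protein for inhibition of alpha-ketoglutarate-dependent dioxygenase alkB homolog 3 (Homo sapiens), read by polymerase chain reaction, with a stated time of 1 h (a higher number here means a weaker inhibitor, a lower number a stronger inhibitor), compound 1 gives 810 nM. Compound 2 `COc1ccc(Cc2c(C)[nH]n(-c3nc4ccccc4[nH]3)c2=O)cc1` carries no phenyl on the fused ring system but a methoxy group on the benzyl arene; in this assay compound 2 gives 630 nM. Compound 1 has the highest of the two numbers, and compound 2 stands nearest to it, within the scatter. Compound 3 `Cc1[nH]n(-c2nc3ccccc3[nH]2)c(=O)c1Cc1ccccc1Cl` is reported only as a limit, > 10000 nM. For the measured compounds named here, the single measured one-change step is an at least 15-fold higher number from compound 2 to compound 3 (1.20 log units; beyond the scatter); it rests on (the limit of > 10000 nM in this assay, at which 1 of the 3 values shown sits), so its size is a floor, not a number.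

Compound 4 `Cc1ccc2[nH]c(-n3[nH]c(C)c(Cc4ccccc4)c3=O)nc2c1` differs from compound 1 at the fused ring system: methyl in place of phenyl on an aromatic carbon. Going by the values given here, no measured step touches that position; the one measured step concerns the benzyl arene and does not carry over. Compound 1 and compound 2, which differ at the fused ring system among other places, give numbers within the scatter of each other. On that basis compound 4 is expected to show a 1.2-fold higher number from compound 1 to compound 4 (0.09 log units; within the scatter), that is, no change beyond the scatter. The estimate for compound 4 is 1000 nM, with a range from 300 nM to 4000 nM.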

Compound 4, half-maximal inhibitory concentration: 670 nM
Beside the measured number, compound 4's estimate is 1.5-fold (0.17 log units) above it, and the stated range covers the measured number.
By their numbers in this assay, from the lowest: compounds 2, 4 and 1 (each within the scatter of the next). At a limit, above all of these: compound 3.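

In this assay, the step at this position reads a 1.2-fold lower number from compound 1 to compound 4 (0.08 log units; within the scatter), the first measured change made on this aromatic carbon alone. Going from phenyl, with 6 heavy atoms and one six-membered aromatic ring of carbon only, to methyl, with 1 heavy atom and no ring, moves the number no further than the scatter when the plain benzyl group stays in place. Compound 1 and compound 2 differ in more than one place and could not isolate this position, so the flat result is new information, although no data shown here give a reason for it.

Open, as far as these compounds go, is whether a carboxylic acid, an amine or a longer chain on this aromatic carbon would also leave the number within the scatter, since phenyl and methyl carry no hydrogen-bond donors or acceptors and no net charge. Also open, from the compounds shown here alone, is whether the same insensitivity holds when the benzyl arene is changed, as with the 2-chlorophenyl group of compound 3 or the 4-methoxyphenyl group of compound 2.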